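A few compounds are considered here, and "the series" means these few. Any claim that something is new, unique, unknown or untested is made for them only; others in the source may bear on it.

Measured in a functional assay on IGROV-1 cells (Homo sapiens) for inhibition, read by sulforhodamine B assay, with a stated time of 48 h; a lower number here means a stronger inhibitor of growth, a higher number a weaker inhibitor of growth:
Compound 1 `Cc1ccc(C2=NN(c3ccc(S(C)(=O)=O)cc3)C(=O)CC2)cc1`: 830 nM
Compound 2 `Cc1cc(O)ccc1C1=NN(c2ccc(S(C)(=O)=O)cc2)C(=O)CC1`: 7130 nM

Of these two compounds, compound 2 gives the higher number, 7130 nM, which makes it the weaker inhibitor of growth of the pair. Compound 3 `CCc1ccc(C2=NN(c3ccc(S(C)(=O)=O)cc3)C(=O)CC2)cc1` has not yet been measured in this assay. Its difference from compound 2 is as follows: 4-ethylphenyl in place of 4-hydroxy-2-methylphenyl on a carbon with a double bond to nitrogen. Thus 4-ethylphenyl stands in place of 4-hydroxy-2-methylphenyl on a carbon with a double bond to nitrogen.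

Within the data shown here, one measured step bears on this change: an 8.6-fold higher number from compound 1 to compound 2 (0.93 log units; beyond the scatter). That modest step is the one that brought in 4-hydroxy-2-methylphenyl, the group that now leaves. A step of similar size in the opposite direction is therefore expected, towards a lower number and close to the level of compound 1. This rests on a single pair, and neither measured compound carries 4-ethylphenyl, so the range stays wide. The estimated change is a 7.9-fold lower number from compound 2 to compound 3 (0.90 log units; beyond the scatter). For compound 3 the expected value is 900 nM, with an estimated range from 350 nM to 2300 nM.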

Compound 3, concentration for 50% growth inhibition: 1480 nM
Compound 3: middle estimate off by 1.6-fold (0.22 log units), on the low side; low and high end bracket the measured number.
By their numbers in this assay, from the lowest: compounds 1 and 3 (each within the scatter of the next); then compound 2.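

In this assay, putting 4-ethylphenyl in place of 4-hydroxy-2-methylphenyl gives a 4.8-fold lower number from compound 2 to compound 3 (0.68 log units; beyond the scatter) and shows that this carbon with a double bond to nitrogen can carry a second alkyl-substituted phenyl group without the high number seen for compound 2. Adding one methyl to the chain of the 4-methylphenyl group gives a 1.8-fold higher number from compound 1 to compound 3 (0.25 log units; within the scatter) and so leaves compound 1 and compound 3 indistinguishable in this measurement, which means the shift from methyl to ethyl has no readable effect here, whereas compound 2 stands apart from both. No independent data accompany these results to explain the separation of compound 2 from the other two compounds.

Compound 2 differs from compound 1 by a hydroxyl and a ring methyl together, so the compounds shown cannot say which of the two accounts for its higher number, and a simple 4-hydroxyphenyl or 2-methylphenyl group would be needed to separate them. From the compounds shown here alone, it also stays open whether a propyl or butyl chain, or a 4-methoxyphenyl or 4-aminophenyl group, would hold the level of compound 1 and compound 3.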